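Three measured compounds, one narrow band

A few compounds are considered here, and "the series" means these few. Any claim that something is new, unique, unknown or untested is made for them only; others in the source may bear on it.

Compound 1 `Nc1nc2cc(Cl)c(Cl)cc2n1Cc1ccc(Cl)cc1` gives 32000 nM
Compound 2 `COc1ccc(Cn2c(N)nc3cc(Cl)c(Cl)cc32)cc1` gives 27000 nM
Compound 3 `CC(C)(C)c1ccc(Cn2c(N)nc3cc(Cl)c(Cl)cc32)cc1` gives 27000 nM

In a functional assay on CEM-SS cells (Homo sapiens) for cytotoxicity (a lower number here means a stronger inhibitor, a higher number a weaker inhibitor), compound 3 stands level with compound 2 at the digits shown, and neither separates from compound 1. The next structure is compound 4 `Nc1nc2cc(Cl)c(Cl)cc2n1Cc1ccc([N+](=O)[O-])cc1`, which carries nitro in place of tert-butyl on an aromatic carbon, para to a large group (nitro in place of tert-butyl on an aromatic carbon). Among the measured compounds shown here, three measured steps bear on this change, each exchanging one group for another: a 1.2-fold lower number from compound 1 to compound 2 (0.07 log units; within the scatter), a 1.2-fold lower number from compound 1 to compound 3 (0.07 log units; within the scatter) and no change at the digits printed from compound 2 to compound 3 (within the scatter). Each of them lies within the scatter. Chloro, methoxy and tert-butyl thus give no separable numbers in this assay, though nitro itself has not been measured and these three compounds are the only evidence. A step beyond the scatter is therefore not expected, and the estimated change, in no firm direction, is a 1.0-fold higher number from compound 3 to compound 4 (0.02 log units; within the scatter). For compound 4 the expected value is 28000 nM, with an estimated range from 13000 nM to 60000 nM.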

Compound 4, half-maximal inhibitory concentration: 32000 nM
For compound 4 the middle estimate is 1.1-fold (0.06 log units) below the measured one, and the stated range covers the measured number.
By their numbers in this assay, from the lowest: compounds 2, 3, 1 and 4 (each within the scatter of the next).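

Among the compounds shown here, exchanging tert-butyl for nitro, on an aromatic carbon para to a large group, gives a 1.2-fold higher number from compound 3 to compound 4 (0.07 log units; within the scatter) in this assay and so leaves the number inside the band of the earlier compounds. The other two exchanges read the same way, with a 1.2-fold higher number from compound 2 to compound 4 (0.07 log units; within the scatter) for nitro in place of methoxy and no change at the digits printed from compound 1 to compound 4 (within the scatter) for nitro in place of chloro. Nitro, the only one of these four groups with hydrogen-bond acceptors, thus gives no number separable from chloro, methoxy or tert-butyl at this position in this assay and nothing further is available here to account for this.

On these data alone, whether an amine, a carboxylic acid or a longer chain at this position would move the number beyond the scatter stays open. Equally open, as far as these compounds go, is whether a change to the shared core, which all four compounds carry unaltered, would do so.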